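The source may hold more compounds than are shown below. What is called first, only, known or untested is meant among the compounds shown, and "the series" means these compounds.

Going by the values given here, in a functional assay on HepG2 cells (Homo sapiens) for inhibition, read by MTT assay, with a stated time of 72 h (on this read-out lower numbers stand for stronger inhibition and higher numbers for weaker inhibition), compound 1 (`Clc1ccc(-c2nnc(SCCCN3CCN(c4nc5ccccc5o4)CC3)o2)cc1`) gives 121000 nM and compound 2 (`COc1ccc(-c2nnc(SCCCN3CCN(c4nc5ccccc5s4)CC3)o2)cc1`) gives 134000 nM as the only two measured values. These values lie within the usual scatter of each other, and compound 2 therefore shows no real separation from compound 1. The next compound to be tested is compound 3 (`Oc1ccc(-c2nnc(SCCCN3CCN(c4nc5ccccc5s4)CC3)o2)cc1`), which differs from compound 2 in one place. The change is hydrogen in place of methyl on an oxygen on an aromatic ring and amounts to hydrogen in place of methyl on an oxygen on an aromatic ring, or 4-methoxyphenyl to 4-hydroxyphenyl. Among the compounds with values here, no two measured compounds differ in one place only, and the data offer no direct precedent for this change. The step of a 1.3-fold lower number from compound 2 to compound 3 (0.13 log units; within the scatter) is expected to stay within the scatter, with no firm direction. The estimated value for compound 3 is 100000 nM with 35000 nM and 220000 nM as the expected ends of its range.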

Compound 3, half-maximal inhibitory concentration: 364000 nM
Estimate against measurement, compound 3: 3.6-fold (0.56 log units) below; the measured number lies above the stated range.
By their numbers in this assay, from the lowest: compounds 1 and 2 (each within the scatter of the next); then compound 3.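

Going from methoxy to hydroxy on the aromatic ring, this assay records a 2.7-fold higher number from compound 2 to compound 3 (0.43 log units; beyond the scatter), the first comparison here of two compounds that differ in one place. The position is therefore not indifferent to this change: in this pair, inhibition is weaker with hydrogen on the oxygen than with methyl, although the step is modest. The data shown offer no measurement that would explain this step.

This single pair cannot separate an effect of the free hydroxy from an effect of losing the methyl, and it does not show whether the same change would give a similar step on the core of compound 1. On these data alone, how an amine or a carboxylic acid in place of the methoxy, or an ethyl or longer chain on the oxygen, would read in this assay also remains open.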